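This account rests on a few compounds, and the source may have more. Where it says the series, first, only, none or still open, it means among the compounds named here.

The measured compounds:
Compound 1, `COc1cc(C(=O)c2sc(-c3ccc(F)cc3)cc2N)cc(OC)c1OC`, gives 16 nM in a functional assay on FM3A cells (Mus musculus) for antiproliferative activity; on this read-out higher numbers stand for weaker inhibition and lower numbers for stronger inhibition.
Compound 2, `COc1cc(C(=O)c2sc(-c3cc(OC)c(OC)c(OC)c3)cc2N)cc(OC)c1OC`, gives 3500 nM.
Compound 3, `COc1cc(C(=O)c2sc(-c3cccc([N+](=O)[O-])c3)cc2N)cc(OC)c1OC`, gives 17 nM.

Compound 3 stands second highest of the three numbers. Its nearest neighbour is compound 1, whose number is lower by a step within the scatter, as the step of a 1.1-fold higher number from compound 1 to compound 3 (0.03 log units; within the scatter) shows. Its furthest neighbour is compound 2, whose number is far higher, well beyond the scatter.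

Compound 4, `COc1cc(C(=O)c2sc(-c3ccccc3Cl)cc2N)cc(OC)c1OC`, has not yet been measured. It differs from compound 3 in one place: 2-chlorophenyl in place of 3-nitrophenyl on an aromatic carbon. Going by the values given here, the step of a 1.1-fold higher number from compound 1 to compound 3 (0.03 log units; within the scatter) is the one measured comparison that bears on it, since there too one substituted phenyl replaced another on the same carbon, and the number barely moved. Compound 4 carries a phenyl with a halogen, as compound 1 does, rather than the 3,4,5-trimethoxyphenyl of compound 2, so the large gap between compound 3 and compound 2 is not expected to repeat. Compound 4 is therefore expected to show a step of about a 1.2-fold higher number from compound 3 to compound 4 (0.07 log units; within the scatter), no more than the scatter, in either direction. The estimated value of compound 4 is 20 nM, with a range from 8 nM to 60 nM.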

Compound 4, half-maximal inhibitory concentration: 34 nM
For compound 4 the middle estimate is 1.7-fold (0.23 log units) below the measured one; the range from low to high includes it.
By their numbers in this assay, from the lowest: compounds 1, 3 and 4 (each within the scatter of the next, the first and the last beyond it); then compound 2.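

On the carbon next to the ring sulfur, the exchange of 3-nitrophenyl, with its 2 hydrogen-bond acceptors, for 2-chlorophenyl, with none, gives in this assay a 2.0-fold higher number from compound 3 to compound 4 (0.30 log units; within the scatter), so this position keeps its low numbers without those acceptors and with a chlorine as the only substituent on the phenyl. The exchange of 4-fluorophenyl for 2-chlorophenyl gives a 2.1-fold higher number from compound 1 to compound 4 (0.33 log units; beyond the scatter), a modest step but the first among the singly substituted phenyl compounds to pass the scatter, and it shows that the choice between two halogen-bearing phenyls can register on this read-out, though compound 4 at 34 nM remains far from compound 2 at 3500 nM. No measured information is available to account for either step.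

The three singly substituted phenyls differ both in the substituent and in where it sits on the ring, so these compounds cannot separate the two. Also open, from the compounds shown here alone, is how this position would respond to a plain phenyl, or to a phenyl carrying an amine or a carboxylic acid, and whether a longer chain could take the place of the phenyl at all.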